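The source may hold more compounds than are shown below. What is called first, only, known or untested is meant among the compounds shown, and "the series" means these compounds.

Within the data shown here, compound 2 `O=[N+]([O-])c1ccc(-c2nc3cc(C(F)(F)F)ccc3[nH]2)cc1` holds the only numerical value in this set: in an ADME assay on MDBK cells (Bos taurus) for cytotoxicity, read by MTT assay, with a stated time of 96 h (on this read-out lower numbers stand for higher toxicity in this test and higher numbers for lower toxicity in this test), compound 2 gives 6000 nM. Compound 1 `O=C(O)CCC(=O)Nc1ccc(-c2nc3cc(C(F)(F)F)ccc3[nH]2)cc1` gives only a limit in this assay, > 100000 nM, and so it sits at the limit of > 100000 nM in this assay, at which 1 of the 2 values shown sits. Among the measured compounds shown here, the single measured step, an at least 16-fold lower number from compound 1 to compound 2 (1.22 log units; beyond the scatter), thus shows a large move to a lower number when nitro takes the place of ((2-carboxyethyl)carbonyl)amino. Compound 3 `CCC(=O)Nc1ccc(-c2nc3cc(C(F)(F)F)ccc3[nH]2)cc1` is not yet measured; it differs from compound 2 by propanoylamino in place of nitro on an aromatic carbon. This change runs opposite to the measured step, restoring an acylamino group where nitro stood, though propanoylamino rather than the ((2-carboxyethyl)carbonyl)amino of compound 1. For compound 3 a rise in the number is therefore expected, a 5.0-fold higher number from compound 2 to compound 3 (0.70 log units; beyond the scatter). Compound 3 is estimated to give 30000 nM in this assay, expected to fall between 8000 nM and 100000 nM, with a real chance that only a limit is reported.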

Compound 3, half-maximal cytotoxic concentration: > 100000 nM
Compound 3: a limit, no number (the forecaster's own chance of this, stated with the estimate: 40%); at least 3.3-fold (0.52 log units) between middle value and limit.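

In this assay, propanoylamino in place of nitro on an aromatic carbon gives an at least 16-fold higher number from compound 2 to compound 3 (1.22 log units; beyond the scatter), so the large change at this position does not need the carboxy group that compound 1 carries at its chain end. Compound 3 gives > 100000 nM, which is a limit and not a number. The step between compound 1 and compound 3 cannot be read, and so far only nitro, in compound 2, gives a number, whereas both acylamino groups end at the same limit: the limit of > 100000 nM in this assay, at which 2 of the 3 values shown sit.

As far as these compounds go, how far either acylamino compound lies past that limit remains open, and so does any order between them. Also open, from the compounds shown here alone, is whether a free amine or a methoxy group on this aromatic carbon would stay at the limit or give a number, as nitro does.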